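Swapping a phenylsulfanyl for a methyl on the core

The source may hold more compounds than are shown below. What is called first, only, known or untested is meant among the compounds shown, and "the series" means these compounds.

Measured so far:
compound 1, `c1ccc(Sc2nn3cc(-c4cc5ccccc5o4)nc3s2)cc1`, "not determined" (no result reported);
compound 2, `COc1nn2cc(-c3cc4ccc(OC)c(OC)c4o3)nc2s1`, 3%.

Compound 1 has the structure `c1ccc(Sc2nn3cc(-c4cc5ccccc5o4)nc3s2)cc1`. In an ADME assay on microsomes from liver (Rattus norvegicus) for metabolic stability, with a stated time of 10 min (a lower number here means that less of the compound is left, a higher number that more of the compound is left), compound 1 gives "not determined" (no result reported), so there is no single number for where it stands; it is the starting point of this step only by its structure. For the measured compounds named here, the one measured neighbour is compound 2, `COc1nn2cc(-c3cc4ccc(OC)c(OC)c4o3)nc2s1`, which in this assay gives 3%, a low share of compound still present after the stated time. Compound 2 differs from compound 1 at more than one place, so its value sets only a loose reference.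

Compound 3 has the structure `Cc1nn2cc(-c3cc4ccccc4o3)nc2s1`. It arises from compound 1 by one change: methyl in place of phenylsulfanyl on an aromatic carbon. The new group is small, and it sits on the shared core.

No number exists for compound 1. The size of the step into compound 3 in this assay therefore cannot be stated from the data; the only anchor is the low value of compound 2. A modest to moderate upward shift from that anchor is expected, but it may also stay within the scatter.

For compound 3 in this assay the expected value is 20%, with a range from 3% to 55%.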

Compound 3, percent of the compound remaining: 4%
Compound 3: middle estimate off by 16 percentage points, on the high side; the measured number falls inside the stated range.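

In this assay, for the compounds shown here, compound 3 gives 4%, while compound 1 gives "not determined" (no result reported), so no step from compound 1 to compound 3 can be read. On these data alone, what replacing phenylsulfanyl with methyl does to the share of compound left therefore stays open. Nothing shown here offers an explanation for the value of compound 3.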